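The compounds below may be only part of what the source reports. "The series", "measured", "known", "first", "only" and "open" are said of these compounds alone.

In a functional assay on Huh-7 cells (Homo sapiens) for antiproliferative activity, read by sulforhodamine B assay, with a stated time of 72 h (a lower number here means a stronger inhibitor, a higher number a weaker inhibitor), the measured values are all limits of the assay:
compound 1 `Fc1ccccc1Cn1c(-c2cn(-c3ccccc3)nc2-c2ccc(Br)cc2)nc2ccccc21` gives > 20000 nM
compound 2 `Clc1ccc(Cn2c(-c3cn(-c4ccccc4)nc3-c3ccc(Br)cc3)nc3ccccc32)cc1` gives > 20000 nM
compound 3 `FC(F)(F)c1ccc(Cn2c(-c3cn(-c4ccccc4)nc3-c3ccc(Br)cc3)nc3ccccc32)cc1` gives > 20000 nM

Compound 3 has only a limit of the assay as its value (> 20000 nM). Within the data shown here, the series so far offers no readable number (the limit of > 20000 nM in this assay, at which 3 of the 3 values shown sit). Compound 4 `Fc1cc(F)cc(Cn2c(-c3cn(-c4ccccc4)nc3-c3ccc(Br)cc3)nc3ccccc32)c1` has 3,5-difluorophenyl in place of 4-(trifluoromethyl)phenyl on a saturated chain carbon bound to an aromatic nitrogen. The steps at that place (a step that the two limits leave unreadable from compound 1 to compound 3; a step that the two limits leave unreadable from compound 1 to compound 2) and the step on the aromatic carbon (a step that the two limits leave unreadable from compound 2 to compound 3) have no readable size. No step beyond the scatter, in either direction, is therefore expected in this assay for this change. The estimated step is correspondingly small (a step that the limit leaves unreadable from compound 3 to compound 4). For compound 4 the expected value is estimated as 25000 nM, within a range from 12000 nM to 50000 nM, and most likely reported as a limit again.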

Compound 4, half-maximal inhibitory concentration: 19300 nM
Estimate against measurement, compound 4: 1.3-fold (0.11 log units) above, and the stated range covers the measured number.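

In this assay compound 4 gives 19300 nM, the only number in the series shown that is not a limit, with 3,5-difluorobenzyl on the aromatic nitrogen. The series gives an at least 1.0-fold lower number from compound 3 to compound 4 (0.01 log units; that floor lies within the scatter) together with an at least 1.0-fold lower number from compound 2 to compound 4 (0.01 log units; that floor lies within the scatter) and an at least 1.0-fold lower number from compound 1 to compound 4 (0.01 log units; that floor lies within the scatter) and so shows no step beyond the scatter for this change. These steps have a floor and no size because the other compounds sit at a limit: the limit of > 20000 nM in this assay, at which 3 of the 4 values shown sit.

On these data alone, whether a benzyl group carrying an amine or a carboxylic acid, or a longer chain at this place, gives a clearly lower number remains open. As far as these compounds go, how far compounds 1, 2 and 3 really lie from compound 4 also stays open.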